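From 4-methoxyphenyl to 4-nitrophenyl in the growth inhibition series

The source may hold more compounds than are shown below. What is called first, only, known or untested is meant among the compounds shown, and "the series" means these compounds.

In a functional assay on MCF7 cells (Homo sapiens) for inhibition, read by sulforhodamine B assay, with a stated time of 48 h (a lower number here means a stronger inhibitor of growth, a higher number a weaker inhibitor of growth), compound 1 (`CC(C)(C)NCc1c(C(=O)O)nn(-c2ccc(Cl)cc2)c1-c1ccccc1`) gives 496000 nM and compound 2 (`COc1ccc(-c2c(CNC(C)(C)C)c(C(=O)O)nn2-c2ccc(Cl)cc2)cc1`) gives 220000 nM. Going by the values given here, compound 2 thus holds the lower of the two numbers so far. Compound 3 (`CC(C)(C)NCc1c(C(=O)O)nn(-c2ccc(Cl)cc2)c1-c1ccc([N+](=O)[O-])cc1`) is the next case, with nitro in place of methoxy on an aromatic carbon. Among the compounds with values here, the only measured step bearing on this change is a 2.3-fold lower number from compound 1 to compound 2 (0.35 log units; beyond the scatter), a modest one with methoxy in place of hydrogen on an aromatic carbon. Within the data shown here, no measured compound carries nitro, so the direction rests on that single step. Compound 3 loses the methoxy of compound 2 and is expected to fall back towards compound 1 in this assay, without a clear move beyond the scatter. The expected step is a 1.5-fold higher number from compound 2 to compound 3 (0.16 log units; within the scatter). Compound 3 is estimated at 320000 nM, with an expected range of 120000 nM to 800000 nM.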

Compound 3, concentration for 50% growth inhibition: 550000 nM
For compound 3 the middle estimate is 1.7-fold (0.24 log units) below the measured one, and the stated range covers the measured number.
By their numbers in this assay, from the lowest: compound 2; then compounds 1 and 3 (each within the scatter of the next).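

In this assay, nitro in place of methoxy gives a 2.5-fold higher number from compound 2 to compound 3 (0.40 log units; beyond the scatter), so the modest gain seen with methoxy is not kept by the nitro group at this aromatic carbon. Nitro in place of hydrogen gives a 1.1-fold higher number from compound 1 to compound 3 (0.04 log units; within the scatter), which places compound 1 and compound 3 within the scatter of each other and leaves compound 2 as the only one of the three set apart from the others at this position. Nothing available here accounts for this difference between the two groups.

As far as these compounds go, whether the gain is specific to methoxy remains open, as a hydroxyl, an amine or a longer ether chain at the same carbon would show. Also open, from the compounds shown here alone, is whether any group at this position can bring the number much lower than that of compound 2.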